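Replacing the Thiophene on the Sulfonyl Sulfur with Chlorophenyl

This account rests on a few compounds, and the source may have more. Where it says the series, first, only, none or still open, it means among the compounds named here.

The compounds here are sulfonamides on a shared core, tested in an ADME assay on HEK293 cells (Homo sapiens) for cytotoxicity, read by resazurin assay, with a stated time of 48 h; a higher number here means that more compound is tolerated, a lower number that less compound is tolerated. Compound 1 `O=S(=O)(Nc1ccc2oc(-c3ccccc3)nc2c1)c1cccc(C(F)(F)F)c1` carries a trifluoromethyl on its sulfonyl-bearing ring. In this assay compound 1 returns only a limit of the assay, > 100000 nM. Compound 2 `O=S(=O)(Nc1ccc2oc(-c3ccccc3)nc2c1)c1cccc(F)c1` differs by a fluoro in place of trifluoromethyl on an aromatic carbon, and in this assay compound 2 gives 68000 nM; that step, an at least 1.4-fold lower number from compound 1 to compound 2 (0.16 log units; that floor lies within the scatter), stays within the scatter of this kind of measurement. Compound 3 `O=S(=O)(Nc1ccc(-c2nc3ccccc3o2)cc1)c1cccs1` carries a thiophen-2-yl on the sulfonyl sulfur. In this assay compound 3 also returns only a limit, > 100000 nM. So two of the three measured compounds sit at the limit of > 100000 nM in this assay, at which 2 of the 3 values shown sit.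

Compound 4 `O=S(=O)(Nc1ccc(-c2nc3ccccc3o2)cc1)c1ccc(Cl)cc1` is the next compound, and its change from compound 3 is 4-chlorophenyl in place of thiophen-2-yl on a sulfonyl sulfur. Going by the values given here, only one measured step exists, the substituent swap from compound 1 to compound 2, and it was small, an at least 1.4-fold lower number from compound 1 to compound 2 (0.16 log units; that floor lies within the scatter); no measured step exchanges a whole ring on the sulfonyl sulfur. With so little to go on, no shift beyond the scatter is expected, and the step of a number no higher from compound 3 to compound 4 (the limit leaves the size open) is therefore estimated as flat. Compound 4 is expected to give about 100000 nM, somewhere between 50000 nM and 200000 nM, quite possibly again as a limit rather than a number.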

Compound 4, half-maximal cytotoxic concentration: > 100000 nM
Compound 4: no number, only a limit; the forecaster's own chance of this, stated with the estimate: 65%; the middle value sits exactly at the limit.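

In this assay compound 4 returns only a limit, > 100000 nM. Going by these compounds alone, compound 3 also stands at a limit, so no step from compound 3 to compound 4 can be read, and most values now sit at the same limit: the limit of > 100000 nM in this assay, at which 3 of the 4 values shown sit. The compounds shown leave open how much of compound 3 and compound 4 is actually tolerated, and whether 4-chlorophenyl in place of thiophen-2-yl changes that at all.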